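Thiadiazolyl on the carbamoyl nitrogen of compound 2

The source may hold more compounds than are shown below. What is called first, only, known or untested is meant among the compounds shown, and "the series" means these compounds.

Measured so far in an in vivo ADME assay on the whole organism for pharmacokinetics, with Mus musculus as the target, at a dose of 5 mg/kg by the intravenous route (a lower number here means that more of the compound stays in the plasma, a higher number that more of the compound sits outside the plasma), for this series

- compound 1 `Nc1nccn2c1c(-c1ccc3ccc(-c4ccccc4)nc3c1F)nc2[C@H]1CC[C@H](C(=O)O)CC1` gives 2.8 L/kg
- compound 2 `Nc1nccn2c1c(-c1ccc3ccc(-c4ccccc4)nc3c1F)nc2[C@H]1CC[C@H](C(N)=O)CC1` gives 2.6 L/kg

Compound 2 stands at 2.6 L/kg in this read-out and lies within the scatter of compound 1, so the two cannot be ranked. Compound 3 `Nc1nccn2c1c(-c1ccc3ccc(-c4ccccc4)nc3c1F)nc2[C@H]1CC[C@H](C(=O)Nc2nncs2)CC1` follows from compound 2 by a single change at the carbamoyl group (1,3,4-thiadiazol-2-yl in place of hydrogen on an amide-type nitrogen) while the shared core stays the same.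

Within the data shown here, one measured step bears on this carbonyl group. It is a 1.1-fold lower number from compound 1 to compound 2 (0.03 log units; within the scatter) and it involves amino in place of hydroxy on the carbonyl carbon. The series holds no measured case of a ring on the amide-type nitrogen, so that step offers only weak guidance and the range must stay wide. Among the measured compounds shown here, with a 1.1-fold lower number from compound 1 to compound 2 (0.03 log units; within the scatter) as the sole precedent, no shift beyond the scatter is expected. The estimated step is a 1.2-fold lower number from compound 2 to compound 3 (0.07 log units; within the scatter) and any direction in it is tentative. For compound 3 the expected value in this assay is 2.2 L/kg with an estimated range from 1 L/kg to 4.5 L/kg as its bounds.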

Compound 3, volume of distribution at steady state: 3.2 L/kg
Compound 3: middle estimate off by 1.5-fold (0.16 log units), on the low side, and the stated range covers the measured number.
By their numbers in this assay, from the lowest: compounds 2, 1 and 3 (each within the scatter of the next).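

In this assay the step reads a 1.2-fold higher number from compound 2 to compound 3 (0.09 log units; within the scatter), so a whole five-membered aromatic ring, 1,3,4-thiadiazol-2-yl in place of hydrogen on an amide-type nitrogen, leaves the read-out within the scatter. Read from the other end of the series, (1,3,4-thiadiazol-2-yl)amino in place of hydroxy on a carbonyl carbon gives a 1.1-fold higher number from compound 1 to compound 3 (0.06 log units; within the scatter), which means that hydroxy, amino and (1,3,4-thiadiazol-2-yl)amino on this carbonyl carbon cannot be ranked among compounds 1, 2 and 3 in this read-out. No measurement in hand offers an explanation for this flat picture.

Open is whether an amine in place of the carbonyl group, or a phenyl ring on the amide-type nitrogen, would move the number beyond the scatter, since the three groups shown at this place span only a narrow set of types. Equally open, going by these compounds, is whether the same flat picture would hold on a different core, as compounds 1, 2 and 3 all share one.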